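The source may hold more compounds than are shown below. What is called first, only, known or untested is meant among the compounds shown, and "the series" means these compounds.

Working notes on a series built on a shared core, with changes at the group on the carbonyl carbon. In a functional assay on MGC-803 cells (Homo sapiens) for cytotoxicity, read by MTT assay, with a stated time of 48 h (a lower number here means a stronger inhibitor, a higher number a weaker inhibitor), compound 1 `CC1=NN(C(=O)c2ccc(C)cc2)C(c2ccccc2O)C1` gives 26300 nM. Compound 2 `CC1=NN(C(=O)COc2ccc(Cl)cc2)C(c2ccccc2O)C1` is recorded as "not active" (no number reported), so it cannot be ranked by number. Compound 3 `CC1=NN(C(=O)CN2CCCCC2)C(c2ccccc2O)C1` gives 4310 nM, the lower of the two numbers available.

The next entry is compound 4 `CC1=NN(C(=O)CN2CCC(c3ccccc3)CC2)C(c2ccccc2O)C1`. The change is phenyl in place of hydrogen on a saturated ring carbon.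

Among the compounds with values here, only one measured step bears on this, and only indirectly: a 6.1-fold lower number from compound 1 to compound 3 (0.79 log units; beyond the scatter). That modest step replaces the whole group on the carbonyl carbon, whereas the new change keeps the (piperidin-1-yl)methyl group and adds to its ring. Within the data shown here, no measured compound carries a substituent on that ring, so the data give no size or direction for this change. Among the measured compounds shown here, compound 2, at "not active" (no number reported), shows only that a different group at the carbonyl carbon can leave no measurable number, which argues for a wide range. The expected outcome in this assay is a 1.2-fold lower number from compound 3 to compound 4 (0.09 log units; within the scatter), a step not expected to exceed the scatter. For compound 4 the estimated value is 3500 nM, with an expected range of 900 nM to 15000 nM.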

Compound 4, half-maximal inhibitory concentration: 12300 nM
Compound 4: the middle estimate sits 3.5-fold (0.55 log units) below what was measured, within the range that was stated.
By their numbers in this assay, from the lowest: compound 3; then compound 4; then compound 1.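

In this assay, the ring of the (piperidin-1-yl)methyl group now has its first measured substituent: phenyl in place of hydrogen, on the saturated ring carbon three ring bonds from the ring nitrogen, gives a 2.9-fold higher number from compound 3 to compound 4 (0.46 log units; beyond the scatter). The earlier compounds shown here changed the whole group on the carbonyl carbon, whereas this step keeps that group and gives the first size and direction for a change on its ring: a modest rise in the number, beyond the scatter. No available evidence bears on what lies behind this rise.

One substituent leaves open whether the rise is specific to phenyl or would also follow from other groups on this ring carbon, such as a methyl group, a hydroxyl group or an amine. Also open, on these data alone, is how the number would respond to a benzyl group at the same carbon, or to a chlorine atom or a carboxylic acid carried on the phenyl ring.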